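Swapping the 4-aminobutyl of compound 3 for sec-butyl

The source may hold more compounds than are shown below. What is called first, only, known or untested is meant among the compounds shown, and "the series" means these compounds.

Measured so far:
Compound 1, `CC(C)[C@H](NC(=O)c1cc2ccccc2cn1)C(=O)OCc1ccccc1`, 29.7%
Compound 2, `O=C(CNC(=O)c1cc2ccccc2cn1)OCc1ccccc1`, 16.1%
Compound 3, `NCCCC[C@H](NC(=O)c1cc2ccccc2cn1)C(=O)OCc1ccccc1`, 40.6%

All three share one core and differ only in the group on a saturated chain carbon bound to an amide-type nitrogen and a carbonyl carbon. In a functional assay on the whole organism (CCRF S-180 cells, Mus musculus) for inhibition, in a xenograft, with stated times of 7 days and 24 h, at a dose of 100 umol/kg by the intraperitoneal route (a lower number here means less inhibition, a higher number more inhibition at the dose given (going by the name of the read-out)), compound 3 stands highest of the three numbers, with the nearest being compound 1 and the furthest compound 2, both beyond the scatter: a number 10.9 percentage points higher from compound 1 to compound 3 (beyond the scatter) and a number 24.5 percentage points higher from compound 2 to compound 3 (beyond the scatter). Compound 4, `CC[C@@H](C)[C@H](NC(=O)c1cc2ccccc2cn1)C(=O)OCc1ccccc1`, has not yet been measured. It differs from compound 3 as follows: sec-butyl in place of 4-aminobutyl on a saturated chain carbon bound to an amide-type nitrogen and a carbonyl carbon. For the measured compounds named here, no measured step introduces sec-butyl, so the bearing steps are indirect. The group entering has, like the isopropyl of compound 1, no hydrogen-bond donor or acceptor, while a number 10.9 percentage points higher from compound 1 to compound 3 (beyond the scatter) shows what the 4-aminobutyl added over isopropyl. A drop of roughly that size is therefore expected, giving a number 10.6 percentage points lower from compound 3 to compound 4 (beyond the scatter). Compound 4 is estimated at 30%, within a range from 15% to 45%.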

Compound 4, a percentage reported as inhibition, in the whole organism at one dose (the size of the read-out at that dose, not a potency): 20.9%
Compound 4: middle estimate off by 9.1 percentage points, on the high side; the range from low to high includes it.
By their numbers in this assay, from the lowest: compounds 2, 4 and 1 (each within the scatter of the next, the first and the last beyond it); then compound 3.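

In this assay, sec-butyl does not keep what 4-aminobutyl gave at this position, with a number 19.7 percentage points lower from compound 3 to compound 4 (beyond the scatter). The other two steps, a number 4.8 percentage points higher from compound 2 to compound 4 (within the scatter) and a number 8.8 percentage points lower from compound 1 to compound 4 (within the scatter), mean that compound 4 cannot be told apart from compound 2, with its hydrogen, or from compound 1, with its isopropyl, so compound 3 alone stands beyond the scatter of all the others. Nothing available here explains why these groups compare as they do.

The compounds shown leave open whether the amine or the length of the 4-aminobutyl chain matters, since a plain butyl chain would separate the two. On these data alone, it is also open whether a shorter aminopropyl chain, or a carboxylic acid at the end of the chain, would match compound 3.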